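Chloro on compound 3: what the limits allow

A few compounds are considered here, and "the series" means these few. Any claim that something is new, unique, unknown or untested is made for them only; others in the source may bear on it.

Compound 1 `CCCCCC(CCO)n1cnc2c(N)nc(Cl)nc21` gives > 50000 nM as a limit
Compound 2 `CCCCCCC(CCO)n1cnc2c(N)nc(Cl)nc21` gives > 50000 nM as a limit
Compound 3 `CCCCCCCC(CCO)n1cnc2c(N)ncnc21` gives > 50000 nM as a limit

All three entries are limits of a functional assay on SW480 cells (Homo sapiens) for antiproliferative activity, read by MTT assay, with a stated time of 48 h (a higher number here means a weaker inhibitor, a lower number a stronger inhibitor), and not numbers, so compound 3 offers no exact starting point. The evidence so far is the limit of > 50000 nM in this assay, at which 3 of the 3 values shown sit, and nothing finer. Compound 4 `CCCCCCCC(CCO)n1cnc2c(N)nc(Cl)nc21` differs from compound 3 by a single change: chloro in place of hydrogen on an aromatic carbon and the rest stays the same. For the measured compounds named here, the only measured step is a step that the two limits leave unreadable from compound 1 to compound 2 and it gives no size to carry over. Compound 2 carries the same chloro and still gives > 50000 nM as a limit. The expected step is an at least 1.1-fold lower number from compound 3 to compound 4 (0.04 log units; that floor lies within the scatter) if any, toward a slightly stronger inhibitor at best. For compound 4 the estimate is 45000 nM within a range of 15000 nM to 100000 nM and a reading at the limit is quite likely.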

Compound 4, half-maximal inhibitory concentration: > 50000 nM
Compound 4 gave a limit, no number; the forecaster's own chance of this, stated with the estimate: 60%; middle value at least 1.1-fold (0.04 log units) from the limit.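

Compound 4 is again a limit and not a number, so its steps to compound 1, compound 2 and compound 3 cannot be read: the limit of > 50000 nM in this assay, at which 4 of the 4 values shown sit. On these data alone, whether the chloro or the chain length changes inhibition in this assay stays open.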